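Iodophenyl swap on the 2-hydroxyethoxy compound

This account rests on a few compounds, and the source may have more. Where it says the series, first, only, none or still open, it means among the compounds named here.

In a functional assay on A-375 cells (Homo sapiens) for cytotoxicity, read by CCK-8 assay, with a stated time of 24 h (on this read-out lower numbers stand for stronger inhibition and higher numbers for weaker inhibition), compound 1 `COc1ccccc1Oc1c(N)nc(-c2ccc(C)cc2)nc1Cl` reads > 80000 nM, a limit of the assay and not a number. Both measured steps start from the limit of > 80000 nM in this assay, at which 1 of the 3 values shown sits. Compound 2 `COc1ccccc1Oc1c(N)nc(-c2ccc(Br)cc2)nc1Cl` gives 63 nM. Compound 3 `COc1ccccc1Oc1c(N)nc(-c2ccc(C)cc2)nc1OCCO` gives 2380 nM, the higher of the two numbers. Bromo in place of methyl gives an at least 1200-fold lower number from compound 1 to compound 2 (3.10 log units; beyond the scatter). 2-Hydroxyethoxy in place of chloro gives an at least 33-fold lower number from compound 1 to compound 3 (1.52 log units; beyond the scatter).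

Compound 4 `COc1ccccc1Oc1c(N)nc(-c2cccc(I)c2)nc1OCCO` carries 3-iodophenyl in place of 4-methylphenyl on an aromatic carbon, with 3-iodophenyl in place of 4-methylphenyl. Going by the values given here, the nearest precedent is compound 2, with an at least 1200-fold lower number from compound 1 to compound 2 (3.10 log units; beyond the scatter), but no measured step tests iodo or this placement. A smaller move in the same direction is therefore expected. The expected step is a 6.0-fold lower number from compound 3 to compound 4 (0.77 log units; beyond the scatter). Compound 4 is estimated at 400 nM, within an expected range of 40 nM to 3000 nM.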

Compound 4, half-maximal inhibitory concentration: 1230 nM
Compound 4: middle estimate off by 3.1-fold (0.49 log units), on the low side, and the stated range covers the measured number.
By their numbers in this assay, from the lowest: compound 2; then compounds 4 and 3 (each within the scatter of the next). At a limit, above all of these: compound 1.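

Going by these compounds alone, with 2-hydroxyethoxy in place, 3-iodophenyl in place of 4-methylphenyl is the first step here that runs between two real numbers, and it stays within the scatter: a 1.9-fold lower number from compound 3 to compound 4 (0.29 log units; within the scatter). The large step of an at least 1200-fold lower number from compound 1 to compound 2 (3.10 log units; beyond the scatter) comes from a chloro compound and finds no match in this swap. The earlier steps from compound 1 start from a limit: the limit of > 80000 nM in this assay, at which 1 of the 4 values shown sits.

Iodo and its placement change together in compound 4, and neither can be read alone. Also open, on these data alone, is what an amine or a carboxylic acid in place of the 2-hydroxyethoxy group would give.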